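The compounds below may be only part of what the source reports. "The series", "measured", "known", "first", "only" and "open" are said of these compounds alone.

Measured compounds:
Compound 1, `O=C1COCCN1c1ccc(/N=C\c2c[nH]c3ccccc23)cc1`, in an ADME assay on BV-2 cells (Mus musculus) for cytotoxicity, read by MTT assay, with a stated time of 48 h, tested at 10 uM (a higher number here means a weaker effect of the compound at the concentration tested, a lower number a stronger effect), gives 98.5%.
Compound 2, `Cc1ccc(S(=O)(=O)n2cc(/C=N\c3ccc(N4CCOCC4=O)cc3)c3ccccc32)cc1`, in this assay gives 86.4%.

Of the two numbers, compound 2 stands lowest, and its nearest neighbour is compound 1, which sits higher by an amount beyond the scatter. Going by the values given here, the one measured step is a number 12.1 percentage points lower from compound 1 to compound 2 (beyond the scatter), a modest lowering tied to the (4-methylphenyl)sulfonyl group placed on the aromatic nitrogen.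

Compound 3, `O=C1COCCN1c1ccc(/N=C\c2cn(C(=O)c3ccccc3)c3ccccc23)cc1`, has not yet been measured in this assay. It differs from compound 2 by benzoyl in place of (4-methylphenyl)sulfonyl on an aromatic nitrogen. The step from compound 1 to compound 2 bears on this change only loosely: it shows that a large group on the aromatic nitrogen can lower the number, but it does not show how benzoyl compares with (4-methylphenyl)sulfonyl. No step beyond the scatter is therefore expected, and the step from compound 2 to compound 3 is estimated at a number 3.6 percentage points higher from compound 2 to compound 3 (within the scatter). Compound 3 is expected to give about 90%, with a range from 78% to 100%.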

Compound 3, a percentage reported as activity, at one concentration (the size of the read-out at that concentration, not a potency): 88.6%
Compound 3: the middle estimate sits 1.4 percentage points above what was measured; low and high end bracket the measured number.
By their numbers in this assay, from the lowest: compounds 2, 3 and 1 (each within the scatter of the next, the first and the last beyond it).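

On the aromatic nitrogen in this assay, benzoyl and (4-methylphenyl)sulfonyl cannot be told apart (a number 2.2 percentage points higher from compound 2 to compound 3 (within the scatter)), so this exchange of one large group for another has no effect that can be read. Set against the hydrogen of compound 1, benzoyl gives a step that stays within the scatter (a number 9.9 percentage points lower from compound 1 to compound 3 (within the scatter)), whereas only the (4-methylphenyl)sulfonyl step was beyond it, so the lowering seen earlier is not clearly shared by both large groups, even though compound 2 and compound 3 themselves do not differ. Nothing given here accounts for these numbers.

As far as these compounds go, it remains open how a small group such as methyl or acetyl on this nitrogen would compare with hydrogen. A chain ending in an amine or a carboxylic acid at this position is equally untested among the compounds shown.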